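The source may hold more compounds than are shown below. What is called first, only, known or untested is meant among the compounds shown, and "the series" means these compounds.

The series rests on two cores. Compound 1 `N=C(N)c1ccc(N2CCC3(CCC(C(=O)NCCC(=O)O)CC3)CC2)cc1` gives 5500 nM in a functional assay with Homo sapiens as the target; on this read-out lower numbers stand for stronger inhibition and higher numbers for weaker inhibition. Going by the values given here, compound 2 `N=C(N)c1ccc(N2CCC3(CCC(C(=O)NCCCC(=O)O)CC3)CC2)cc1` carries carboxymethyl in place of carboxy on a saturated chain carbon, two bonds along the chain from an amide-type nitrogen and gives 37100 nM in this assay; the step of a 6.7-fold higher number from compound 1 to compound 2 (0.83 log units; beyond the scatter) is the only measured example of this change. Compound 3 `O=C(O)CNC1CCC2(CC1)CCN(c1ccncc1)CC2` shows the lowest of the three numbers, 890 nM in this assay; how its core differs from the core of compound 1 is not broken down here. Compound 4 `O=C(O)CCNC1CCC2(CC1)CCN(c1ccncc1)CC2` is not yet measured and differs from compound 3 by carboxymethyl in place of carboxy on a saturated chain carbon bound to an amine nitrogen. Among the compounds with values here, this is the same kind of change as the one from compound 1 to compound 2, though the place is not the same: in compound 1 the carbon lies two bonds along the chain from an amide-type nitrogen, whereas in compound 3 it is bound to an amine nitrogen. With a single earlier example and a different place around the change, the expectation is for a step in the same direction but of smaller size. The expected step is a 3.9-fold higher number from compound 3 to compound 4 (0.59 log units; beyond the scatter) in this assay. Compound 4 is therefore estimated at 3500 nM, with a range from 1000 nM to 12000 nM.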

Compound 4, half-maximal inhibitory concentration: 4500 nM
Estimate against measurement, compound 4: 1.3-fold (0.11 log units) below; measured number inside the range.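

In this assay, the lengthening of the acid chain on the amine nitrogen gives a 5.1-fold higher number from compound 3 to compound 4 (0.70 log units; beyond the scatter), which runs in the same direction as the earlier step on the other core. Set side by side, the two steps cannot be told apart in size: the same change on two cores in this assay, a 6.7-fold higher number (0.83 log units; beyond the scatter) from compound 1 to compound 2 and a 5.1-fold higher number (0.70 log units; beyond the scatter) from compound 3 to compound 4, 1.3-fold (0.13 log units) apart, within the scatter of two such steps This shows that, across these two pairs, the change from carboxy to carboxymethyl carries over from one core to the other, even though its place differs, but it rests on a single pair per core and does not show why the number rises or that the same would hold on any further core.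

The compounds shown leave open whether a still longer chain ending in a carboxylic acid would raise the number further on the amine nitrogen, and whether a tetrazole could stand in for the carboxylic acid on either core. They also leave open what an amide in place of the amine would give on the core of compound 3.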